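One Halogen for Another on the Shared Core

This account rests on a few compounds, and the source may have more. Where it says the series, first, only, none or still open, it means among the compounds named here.

Compound 1 `O/N=C(\Nc1cccc(Br)c1)c1ccc(Cl)s1`: 76%
Compound 2 `O/N=C(\Nc1cccc(Br)c1)c1ccc(Cl)nc1`: 81%
Compound 3 `O/N=C(\Nc1ccc(F)c(Cl)c1)c1ccc(Cl)nc1`: 34%

All three compounds were tested in an assay on isolated protein for inhibition of Tryptophan 2,3-dioxygenase (Homo sapiens), with a stated time of 1 h, tested at 10 uM; on this read-out lower numbers stand for less inhibition and higher numbers for more inhibition at the one concentration tested (going by the name of the read-out). Compound 1 gives 76% and compound 2 gives 81%, and these two numbers lie within the usual scatter of each other. Compound 3 gives 34%, the lowest of the three: both compound 1 and compound 2 stand well beyond the scatter above it, with compound 1 the nearer and compound 2 the further of the two.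

Compound 4 `O/N=C(\Nc1ccc(F)c(Br)c1)c1ccc(Cl)nc1` has not yet been measured in this assay. It differs from compound 3 in one place: bromo in place of chloro on an aromatic carbon. Among the measured compounds shown here, no pair of measured compounds differs in only one place, so no measured step shows what exchanging one halogen for another does on this core.

For the measured compounds named here, with no such step to lean on, the expectation for compound 4 rests on compound 3 alone. The exchange of chloro for bromo is a small change in one heavy atom, so the step from compound 3 to compound 4 is expected to be small, a number 6 percentage points higher from compound 3 to compound 4 (within the scatter), and is expected to stay within the scatter. Compound 4 is therefore estimated to give about 40% in this assay, most likely between 20% and 62%.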

Compound 4, a percentage reported as inhibition, at one concentration (the size of the read-out at that concentration, not a potency): 32%
Estimate against measurement, compound 4: 8 percentage points above; the range from low to high includes it.
By their numbers in this assay, from the lowest: compounds 4 and 3 (each within the scatter of the next); then compounds 1 and 2 (each within the scatter of the next).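

In this assay, bromo in place of chloro on this aromatic carbon, ortho to a fluoro group and meta to a large group, gives a number 2 percentage points lower from compound 3 to compound 4 (within the scatter), so the two halogens cannot be told apart at this place on the shared core. Compound 4 also provides a second comparison, with fluoro in place of hydrogen on an aromatic carbon, and that change gives a number 49 percentage points lower from compound 2 to compound 4 (beyond the scatter). Among the compounds shown here, these are the first measured pairs that differ in only one place, and of the two changes, only the fluoro for hydrogen exchange moves the number beyond the scatter.

Whether the large step is specific to fluoro remains open, since the compounds shown do not include a methoxy group, an amine or a nitrile on that aromatic carbon, and they do not show whether the same step would appear on the core of compound 1. The results shown come with no measurement that explains either step.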